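Hydrogen in place of methoxy: compound 2 to compound 4

This account rests on a few compounds, and the source may have more. Where it says the series, first, only, none or still open, it means among the compounds named here.

Measured compounds in a functional assay on BT-549 cells (Homo sapiens) for cytotoxicity, read by sulforhodamine B assay, with a stated time of 48 h, tested at 1 uM; a lower number here means a stronger effect, a higher number a weaker effect of the compound at the concentration tested:
Compound 1 `COc1ccc(-c2cc(/C=C/C(=O)c3ccc(N)cc3)[nH]n2)cc1` gives 77%.
Compound 2 `COc1cc(-c2cc(/C=C/C(=O)c3ccc(N)cc3)[nH]n2)cc(OC)c1OC` gives 73%.
Compound 3 `COc1ccc(C(=O)/C=C/c2cc(-c3cc(OC)c(OC)c(OC)c3)n[nH]2)cc1` gives 93%.

Compound 2 has the lowest of the three numbers. Its nearest neighbour is compound 1, whose number is within the scatter of that of compound 2. Going by the values given here, the furthest is compound 3, reached by the only single-point step recorded so far: a number 20 percentage points higher from compound 2 to compound 3 (beyond the scatter).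

Compound 4 `COc1ccc(-c2cc(/C=C/C(=O)c3ccc(N)cc3)[nH]n2)cc1OC` is not yet measured. It differs from compound 2 as follows: hydrogen in place of methoxy on an aromatic carbon

Among the compounds with values here, no measured step covers this change. The step from compound 2 to compound 3 alters the amino group, not a methoxy, and so says nothing about it. What the numbers do show is that compound 1 and compound 2, both carrying the amino ketone that compound 4 also keeps, lie within the scatter of each other. On that basis compound 4 is expected to give a number close to that of compound 2, with a step of a number 2 percentage points higher from compound 2 to compound 4 (within the scatter), not beyond the scatter in either direction. The estimate for compound 4 in this assay is 75%, with a range from 62% to 88%.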

Compound 4, a percentage reported as activity, at one concentration (the size of the read-out at that concentration, not a potency): 80%
For compound 4 the middle estimate is 5 percentage points below the measured one; the range from low to high includes it.
By their numbers in this assay, from the lowest: compounds 2, 1 and 4 (each within the scatter of the next); then compound 3.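

Hydrogen in place of methoxy on the six-membered aromatic ring of carbon only, at the place ortho to a methoxy group and meta to a large group, can now be read directly in this assay: a number 7 percentage points higher from compound 2 to compound 4 (within the scatter). The reverse kind of change gives a number 3 percentage points higher from compound 1 to compound 4 (within the scatter), so compound 1, compound 4 and compound 2, which all keep the amino ketone, are linked by steps that stay within the scatter. Among these three compounds, this methoxy position therefore shows no separable effect on the read-out, unlike the change at the other end of the molecule, a number 20 percentage points higher from compound 2 to compound 3 (beyond the scatter). No available evidence bears on this result.

Still open, from the compounds shown here alone, is whether a hydroxyl group, a chlorine atom or an ethoxy chain at this position would give a step beyond the scatter. Since the read-out comes from a single concentration, it shows only whether the effect of these compounds is stronger or weaker at that concentration, and any difference among them at other concentrations cannot be judged from this assay.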